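Cyclohexyl-imidazopyridine series: aryl swap at the pyrazine position

This account rests on a few compounds, and the source may have more. Where it says the series, first, only, none or still open, it means among the compounds named here.

Measured so far:
compound 1 `c1ccc(-c2cn3ccnc3c(-c3ccc4ncn(C5CCCCC5)c4c3)n2)cc1` — 58.1%
compound 2 `Brc1ccc(-c2cn3ccnc3c(-c3ccc4ncn(C5CCCCC5)c4c3)n2)cc1` — 35.5%

In a functional assay on NCI-H522 cells (Homo sapiens) for inhibition, read by sulforhodamine B assay, with a stated time of 48 h, tested at 10 uM (on this read-out higher numbers stand for more inhibition at the one concentration tested (going by the name of the read-out) and lower numbers for less inhibition), compound 2 stands lowest of the two numbers; its nearest neighbour is compound 1, and the step of a number 22.6 percentage points lower from compound 1 to compound 2 (beyond the scatter) lies beyond the scatter.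

Compound 3 `c1csc(-c2cn3ccnc3c(-c3ccc4ncn(C5CCCCC5)c4c3)n2)c1` is not yet measured. Relative to compound 2 the change is thiophen-2-yl in place of 4-bromophenyl on an aromatic carbon.

Among the measured compounds shown here, no measured step covers the exchange of one aromatic ring for another; the only step in hand, a number 22.6 percentage points lower from compound 1 to compound 2 (beyond the scatter), concerns a bromine added to the phenyl ring and does not directly transfer. Because compound 1 carries an unsubstituted ring and gives 58.1%, an unsubstituted five-membered ring is expected to lie nearer to compound 1 than to compound 2, so a rise of a number 14.5 percentage points higher from compound 2 to compound 3 (beyond the scatter) is expected in this assay. For compound 3 the estimate is 50%, with a range from 25% to 72%.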

Compound 3, a percentage reported as inhibition, at one concentration (the size of the read-out at that concentration, not a potency): 13.2%
Compound 3: middle estimate off by 36.8 percentage points, on the high side; measured number below the stated range.
By their numbers in this assay, from the lowest: compound 3; then compound 2; then compound 1.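

In this assay the position responds to the identity of the ring itself, not only to substitution on the phenyl ring: the change shows as a number 44.9 percentage points lower from compound 1 to compound 3 (beyond the scatter) and leaves compound 3 lowest of the series. An unsubstituted ring therefore does not by itself keep the number close to that of compound 1, and removing the bromine does not restore it, as a number 22.3 percentage points lower from compound 2 to compound 3 (beyond the scatter) shows for the exchange of 4-bromophenyl for thiophen-2-yl. No measurement in hand accounts for this fall.

Still open, on these data alone, is whether the lower number goes with the five-membered ring or with the sulfur atom, which furan-2-yl or pyridin-2-yl at this carbon would begin to separate. Also open, as far as these compounds go, is how a phenyl ring carrying an amine or a carboxylic acid would read here.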